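From Acetyl to Dimethylamino: One Cytotoxicity Step

The compounds below may be only part of what the source reports. "The series", "measured", "known", "first", "only" and "open" are said of these compounds alone.

The study measures how strongly a small set of compounds sharing one core affect EKVX cells in a functional assay on EKVX cells (Homo sapiens) for cytotoxicity, read by sulforhodamine B assay, with a stated time of 48 h, tested at 0.001 uM; a lower number here means a stronger effect, a higher number a weaker effect of the compound at the concentration tested. Compound 1, with the structure `COc1cc(C)cc(-c2c(-c3ccnc(-c4ccc(C(C)=O)cc4)c3)cnn2CC#N)c1`, gives 95%. Compound 2, with the structure `COc1cc(C)cc(-c2nn(CC#N)cc2-c2ccc(-c3cccc(C(C)=O)c3)nc2)c1`, gives 99%, and compound 3, with the structure `Cc1cc(O)cc(-c2nn(CC#N)cc2-c2ccnc(-c3ccc(Oc4ccccc4)cc3)c2)c1`, gives 103%. Compound 1 thus stands in one band with compound 2 and compound 3: the gaps from compound 1 to each of the other two are within the usual scatter, so the three numbers show no difference that can be read as a real one at this concentration.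

Compound 4, with the structure `COc1cc(C)cc(-c2c(-c3ccnc(-c4ccc(N(C)C)cc4)c3)cnn2CC#N)c1`, has not yet been measured. It differs from compound 1 in one place: dimethylamino in place of acetyl on an aromatic carbon. Going by the values given here, no step between two measured compounds is available for this kind of exchange, so nothing in the data points to a large effect in either direction. Since the three measured compounds all sit close together, the step from compound 1 to compound 4 is expected to be none beyond the scatter, as a number 3 percentage points higher from compound 1 to compound 4 (within the scatter) expresses. For compound 4 the estimate in this assay is 98%, with a range from 88% to 108%.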

Compound 4, a percentage reported as activity, at one concentration (the size of the read-out at that concentration, not a potency): 97%
For compound 4 the middle estimate is 1 percentage points above the measured one; measured number inside the range.
By their numbers in this assay, from the lowest: compounds 1, 4, 2 and 3 (each within the scatter of the next).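

The exchange of 4-acetylphenyl for 4-(dimethylamino)phenyl gives the first step read directly at this position in this assay, and it comes out as a number 2 percentage points higher from compound 1 to compound 4 (within the scatter). On this aromatic carbon, para to a large group, replacing acetyl with dimethylamino, a group with the same count of heavy atoms, therefore leaves no difference that can be read at the concentration tested. Nothing at hand speaks to why the two groups give readings within the scatter of each other.

The compounds shown leave open whether a carboxylic acid, a primary amine or a longer alkyl chain at this position would move the reading beyond the scatter. They also leave open whether acetyl and dimethylamino would stay alike at a higher concentration, where a larger effect could be read.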